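Allyl in place of hydrogen on compound 2

The compounds below may be only part of what the source reports. "The series", "measured", "known", "first", "only" and "open" are said of these compounds alone.

In a functional assay on SK-OV-3 cells (Homo sapiens) for antiproliferative activity, with a stated time of 48 h (a lower number here means a stronger inhibitor, a higher number a weaker inhibitor), compound 1 (`C=CCN1c2c(N)nc(N)nc2CCC1CN(C)c1ccc(C(=O)N[C@@H](CCC(=O)O)C(=O)O)cc1`) gives 573 nM and compound 2 (`C=CCN1c2c(N)nc(N)nc2CCC1CNc1ccc(C(=O)N[C@@H](CCC(=O)O)C(=O)O)cc1`) gives 870 nM, so the two stand within the scatter of each other. Compound 3 (`C=CCN(CC1CCc2nc(N)nc(N)c2N1CC=C)c1ccc(C(=O)N[C@@H](CCC(=O)O)C(=O)O)cc1`) differs from compound 2 by allyl in place of hydrogen on a nitrogen on an aromatic ring. Going by the values given here, one measured step bears on this place, the exchange of methyl for hydrogen, a 1.5-fold higher number from compound 1 to compound 2 (0.18 log units; within the scatter). Among the compounds with values here, no allyl analogue has a value yet, so no firm direction is expected in this assay. The expected step is a 1.2-fold lower number from compound 2 to compound 3 (0.09 log units; within the scatter), none beyond the scatter. For compound 3 the estimated value is 700 nM, with an expected range of 280 nM to 1800 nM.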

Compound 3, half-maximal inhibitory concentration: 50200 nM
The estimate for compound 3 lay 72-fold (1.86 log units) below the measured number; measured number above the stated range.
By their numbers in this assay, from the lowest: compounds 1 and 2 (each within the scatter of the next); then compound 3.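

In this assay the nitrogen on an aromatic ring proves sensitive to its substituent: allyl in place of hydrogen gives a 58-fold higher number from compound 2 to compound 3 (1.76 log units; beyond the scatter) and marks a clear loss of activity, whereas hydrogen and methyl there stand within the scatter of each other. The step read from the methyl-bearing side is an 88-fold higher number from compound 1 to compound 3 (1.94 log units; beyond the scatter) and points the same way. As far as these compounds go, whether the double bond of allyl matters stays open, and a propyl or ethyl chain on this nitrogen would bear on that. No measurement at hand gives a cause for this loss.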